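Solubility outlook for compound 4 beside compounds 1 to 3

A few compounds are considered here, and "the series" means these few. Any claim that something is new, unique, unknown or untested is made for them only; others in the source may bear on it.

Measured so far in a physicochemical assay for solubility, in phosphate buffer, at pH 7.4; on this read-out lower numbers stand for lower solubility and higher numbers for higher solubility:
Compound 1 `OC1CN(c2nccnc2OC2CN(c3ccc4ccccc4n3)C2)C1` gives 41000 nM.
Compound 2 `COCC1CCN(c2nccnc2OC2CN(c3ccc4ccccc4n3)C2)CC1` gives 53000 nM.
Compound 3 `CN(C)C1CCN(c2nccnc2OC2CN(c3ccc4ccccc4n3)C2)CC1` gives 500000 nM.

Compound 2 holds the second highest of the three numbers. Its nearest neighbour is compound 1, with a 1.3-fold higher number from compound 1 to compound 2 (0.11 log units; within the scatter), so the two are not separated in this assay. Its furthest neighbour is compound 3, with a 9.4-fold higher number from compound 2 to compound 3 (0.97 log units; beyond the scatter). The largest step in the set is a 12-fold higher number from compound 1 to compound 3 (1.09 log units; beyond the scatter).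

Compound 4 `c1ccc2nc(N3CC(Oc4nccnc4-c4cccc5ncccc45)C3)ccc2c1` is the untested member. Against compound 2 the change is quinolin-5-yl in place of 4-(methoxymethyl)piperidin-1-yl on an aromatic carbon.

Among the measured compounds shown here, none of the measured steps covers this kind of exchange. The two steps beyond the scatter, a 12-fold higher number from compound 1 to compound 3 (1.09 log units; beyond the scatter) and a 9.4-fold higher number from compound 2 to compound 3 (0.97 log units; beyond the scatter), both bring in the dimethylamino group, which compound 4 does not carry; the third, a 1.3-fold higher number from compound 1 to compound 2 (0.11 log units; within the scatter), swaps one saturated ring substituent for another and stays within the scatter. For the measured compounds named here, a quinolin-5-yl entering for 4-(methoxymethyl)piperidin-1-yl therefore has no direct precedent here, and the expectation rests on the structural change alone: a step downward, beyond the scatter, is expected, a 5.3-fold lower number from compound 2 to compound 4 (0.72 log units; beyond the scatter).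

Compound 4 is estimated at 10000 nM, with a range from 2000 nM to 40000 nM.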

Compound 4, solubility: 47000 nM
For compound 4 the middle estimate is 4.7-fold (0.67 log units) below the measured one; the whole stated range lies below it.
By their numbers in this assay, from the lowest: compounds 1, 4 and 2 (each within the scatter of the next); then compound 3.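

At the aromatic carbon of the six-membered aromatic ring with 2 nitrogen, the exchange to quinolin-5-yl leaves the number in this assay inseparable from those of the two earlier groups (a 1.1-fold lower number from compound 2 to compound 4 (0.05 log units; within the scatter); a 1.1-fold higher number from compound 1 to compound 4 (0.06 log units; within the scatter)), so this place accepts a group with no saturated ring and no separation appears among compounds 1, 2 and 4. Among the compounds shown here, compound 3 remains the only compound apart from the others, and the new comparison extends that gap to the quinolin-5-yl compound (an 11-fold lower number from compound 3 to compound 4 (1.03 log units; beyond the scatter)); among the four compounds, 4-(dimethylamino)piperidin-1-yl is the one group at this place linked to a step beyond the scatter. No supporting measurement accompanies these results, so the compounds offer no explanation for either the shared level or the position of compound 3.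

Open, on these data alone, is whether a piperazin-1-yl group, a primary amine or a carboxylic acid at this place would join compound 3 or stay with compounds 1, 2 and 4. Also open, as far as these compounds go, is whether a dimethylamino group carried on the quinolin-5-yl ring would give a step of similar size to that seen on the piperidine.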